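A few compounds are considered here, and "the series" means these few. Any claim that something is new, unique, unknown or untested is made for them only; others in the source may bear on it.

Measured in a functional assay on MCF7 cells (Homo sapiens) for inhibition; on this read-out lower numbers stand for stronger inhibition and higher numbers for weaker inhibition:
Compound 1 `Cc1cc(C)c2nc(Cl)c([C@@H]3[C@@H](C(=O)c4ccccc4)C4(c5ccccc5-c5nc6ccccc6nc54)N4CSC[C@@H]34)cc2c1` gives 11000000 nM
Compound 2 `COc1ccc2nc(Cl)c([C@@H]3[C@@H](C(=O)c4ccccc4)C4(c5ccccc5-c5nc6ccc(C(=O)c7ccccc7)cc6nc54)N4CSC[C@@H]34)cc2c1` gives 14000000 nM

Compound 1 stands level with compound 2 on these numbers, the two lying within the usual scatter of each other. Compound 3 `Cc1cc(C)c2nc(Cl)c([C@@H]3[C@@H](C(=O)c4ccccc4)C4(c5ccccc5-c5nc6ccc(C(=O)c7ccccc7)cc6nc54)N4CSC[C@@H]34)cc2c1` has not yet been measured. It keeps the core of compound 1 and carries one change, benzoyl in place of hydrogen on an aromatic carbon of a six-membered aromatic ring of carbon only. Within the data shown here, no measured pair shows this change alone, so the data hold no direct step for it. Compound 2 also bears a benzoyl group, and compound 2 gives 14000000 nM in this reading, so no shift beyond the scatter is expected in this assay here. The estimated step, a 1.1-fold higher number from compound 1 to compound 3 (0.04 log units; within the scatter), is expected to stay within the scatter. Compound 3 is expected to give about 12000000 nM in the estimate, with a likely range from 6000000 nM to 25000000 nM when it is measured.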

Compound 3, half-maximal inhibitory concentration: 11000000 nM
Estimate against measurement, compound 3: 1.1-fold (0.04 log units) above, and the stated range covers the measured number.
By their numbers in this assay, from the lowest: compounds 1, 3 and 2 (each within the scatter of the next).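

In this assay, benzoyl in place of hydrogen on an aromatic carbon now has a direct reading, with no change at the digits printed from compound 1 to compound 3 (within the scatter), and the rest of the structure stays the same. This position, on a six-membered aromatic ring of carbon only, meta to a fused ring and para to a fused ring, therefore takes the added benzoyl without a shift beyond the scatter, at least on the core of compound 1. No measurement at hand offers an explanation for this result.

The compounds shown leave open whether an amine or a carboxylic acid at this same place would also leave the number within the scatter. Among these compounds, with only one direct pair, they also leave open whether benzoyl behaves in the same way on other cores.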